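From 3-nitrophenyl to 2-chlorophenyl on a shared core

A few compounds are considered here, and "the series" means these few. Any claim that something is new, unique, unknown or untested is made for them only; others in the source may bear on it.

In a functional assay on SK-N-SH cells (Homo sapiens) for cytotoxicity, read by MTT assay, with a stated time of 24 h (on this read-out lower numbers stand for stronger inhibition and higher numbers for weaker inhibition), compound 1 (`C/C(=N\NC(=O)/C(C#N)=C/c1ccc(O)cc1)c1c(O)c2ccc(O)cc2oc1=O`) gives 8120 nM and compound 2 (`C/C(=N\NC(=O)/C(C#N)=C/c1ccc(Br)cc1)c1c(O)c2ccc(O)cc2oc1=O`) gives 12100 nM while compound 3 (`C/C(=N\NC(=O)/C(C#N)=C/c1cccc([N+](=O)[O-])c1)c1c(O)c2ccc(O)cc2oc1=O`) gives 28300 nM as the highest number of the three. Compound 4 (`C/C(=N\NC(=O)/C(C#N)=C/c1ccccc1Cl)c1c(O)c2ccc(O)cc2oc1=O`) carries 2-chlorophenyl in place of 3-nitrophenyl on a double-bonded chain carbon bound to a double-bonded chain carbon. Among the compounds with values here, two measured steps bear on this change, (a 2.3-fold higher number from compound 2 to compound 3 (0.37 log units; beyond the scatter)) and (a 3.5-fold higher number from compound 1 to compound 3 (0.54 log units; beyond the scatter)), and both are modest. A third (a 1.5-fold higher number from compound 1 to compound 2 (0.17 log units; within the scatter)) stays within the scatter. Compound 4 carries a halogen, as compound 2 does, so the first step is the closer guide. The expected step is a 2.2-fold lower number from compound 3 to compound 4 (0.34 log units; beyond the scatter) in this assay and points to a lower number. For compound 4 the estimate is 13000 nM with an expected range from 6000 nM to 29000 nM.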

Compound 4, half-maximal inhibitory concentration: 14000 nM
Compound 4: the middle estimate sits 1.1-fold (0.03 log units) below what was measured, within the range that was stated.
By their numbers in this assay, from the lowest: compounds 1, 2 and 4 (each within the scatter of the next); then compound 3.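

In this assay, a 2.0-fold lower number from compound 3 to compound 4 (0.31 log units; beyond the scatter) is a step beyond the scatter, which leaves compound 3 with the highest number of the four. Changing the ring on the double-bonded chain carbon otherwise makes no clear difference, since a 1.2-fold higher number from compound 2 to compound 4 (0.06 log units; within the scatter) and a 1.7-fold higher number from compound 1 to compound 4 (0.24 log units; within the scatter) both stay within the scatter. No measurement shown accounts for why compound 3 stands apart.

Each of these rings differs in both its group and where that group sits, so the two cannot be separated for 3-nitrophenyl. As far as these compounds go, whether an amine or a carboxylic acid on this ring would shift the number remains open.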